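Methyl on the amine: one change tried twice

A few compounds are considered here, and "the series" means these few. Any claim that something is new, unique, unknown or untested is made for them only; others in the source may bear on it.

Measured in a functional assay on HeLa cells (Homo sapiens) for antiproliferative activity, read by MTT assay, with a stated time of 48 h; on this read-out higher numbers stand for weaker inhibition and lower numbers for stronger inhibition:
compound 1 `C=C(c1ccc(OC)cc1NC(=O)CN)c1ccc(OC)c2c1C=CC(C)(C)O2` gives 200 nM;
compound 2 `C=C(c1cc(OC)c(OC)c(OC)c1)c1ccc(OC)cc1NC(=O)CN` gives 70 nM;
compound 3 `C=C(c1ccc(OC)cc1NC(=O)CNC)c1ccc(OC)c2c1C=CC(C)(C)O2` gives 500 nM.

Compound 1 and compound 3 share a core and differ in one place: methyl in place of hydrogen on an amine nitrogen. That change brought a 2.5-fold higher number from compound 1 to compound 3 (0.40 log units; beyond the scatter), a modest weakening. Compound 2 carries a different core; how the two cores differ is not broken down here, but compound 2 gives the lowest number of the three. Compound 4 `C=C(c1cc(OC)c(OC)c(OC)c1)c1ccc(OC)cc1NC(=O)CNC` stands to compound 2 as compound 3 stands to compound 1, since the difference methyl in place of hydrogen on an amine nitrogen sits at a place described in exactly the same words, making it the same change. Among the measured compounds shown here, because the single earlier instance gave a 2.5-fold higher number from compound 1 to compound 3 (0.40 log units; beyond the scatter), a step of similar size is expected, a 2.5-fold higher number from compound 2 to compound 4 (0.40 log units; beyond the scatter). Compound 4 is therefore estimated at 175 nM in this assay, plausibly between 80 nM and 400 nM.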

Compound 4, half-maximal inhibitory concentration: 140 nM
Compound 4: the middle estimate sits 1.3-fold (0.10 log units) above what was measured; the range from low to high includes it.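

In this assay methyl in place of hydrogen on the amine nitrogen gave a 2.0-fold higher number from compound 2 to compound 4 (0.30 log units; within the scatter) and so, taken alone, this step cannot be told apart from the scatter of repeated measurements. Set beside the earlier step, the change looks much the same size on both cores: the same change on two cores in this assay, a 2.5-fold higher number (0.40 log units; beyond the scatter) from compound 1 to compound 3 and a 2.0-fold higher number (0.30 log units; within the scatter) from compound 2 to compound 4, 1.3-fold (0.10 log units) apart, within the scatter of two such steps
This is agreement between just two cores in one assay, which makes carrying the change over look reasonable here but gives no rule for any other core.

The compounds shown leave open whether a larger group on this nitrogen, such as ethylamino or dimethylamino in place of amino, would shift the number further. They also leave open whether the step would hold on a third core.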